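Guanidine tail variation in a melanocortin receptor 4 series

This account rests on a few compounds, and the source may have more. Where it says the series, first, only, none or still open, it means among the compounds named here.

Measured so far:
compound 1 `COc1ccc(Br)cc1CCc1c(F)cccc1C(=O)/N=C(\N)NCCN1CCCC1`: 190 nM
compound 2 `COc1ccc(Br)cc1CCc1c(F)cccc1C(=O)/N=C(\N)NCCCCN(C)Cc1ccccc1`: 5.1 nM

In an assay for binding affinity to Melanocortin receptor 4 (Homo sapiens) (a lower number here means a stronger inhibitor, a higher number a weaker inhibitor), compound 1 gives 190 nM, while compound 2 gives 5.1 nM and so stands with the lowest number of the two. Going by the values given here, the single measured step, a 37-fold lower number from compound 1 to compound 2 (1.57 log units; beyond the scatter), is large and exchanges the pyrrolidine tail for a chain ending in a benzyl(methyl)amino group.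

Compound 3 `COc1ccc(Br)cc1CCc1c(F)cccc1C(=O)/N=C(\N)NCC1CCNCC1` is not yet measured. It differs from compound 2 by piperidin-4-yl in place of 3-(benzyl(methyl)amino)propyl on a saturated chain carbon bound to an amine nitrogen. The step that bears on this is a 37-fold lower number from compound 1 to compound 2 (1.57 log units; beyond the scatter). It shows how far the number moved when a simple cyclic amine was exchanged for the benzyl-bearing tail. Compound 3 gives that tail up again and returns to a cyclic amine, now with a ring nitrogen carrying a hydrogen, so in this assay a step upward, back toward compound 1, is expected for compound 3, of roughly a 20-fold higher number from compound 2 to compound 3 (1.29 log units; beyond the scatter). The value expected for compound 3 is therefore 100 nM, with a range from 25 nM to 400 nM.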

Compound 3, inhibition constant: 13 nM
Beside the measured number, compound 3's estimate is 7.7-fold (0.89 log units) above it, outside the stated range (below it).
By their numbers in this assay, from the lowest: compound 2; then compound 3; then compound 1.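

In this assay the exchange of the 3-(benzyl(methyl)amino)propyl tail for piperidin-4-yl costs little, with a 2.5-fold higher number from compound 2 to compound 3 (0.41 log units; beyond the scatter), so a low number at this position does not depend on keeping the benzyl group. Piperidin-4-yl in place of (pyrrolidin-1-yl)methyl gives a 15-fold lower number from compound 1 to compound 3 (1.16 log units; beyond the scatter), which shows that two cyclic amine tails can sit far apart and that a cyclic amine does not by itself bring a high number. The large step from the pyrrolidine tail to the benzyl-bearing tail therefore cannot be read as a gain from the benzyl group alone, since compound 3 comes close to compound 2 without it.

No measurement at hand explains the gap between the two cyclic amine tails. The compounds shown do not separate ring size, attachment through a ring carbon and the hydrogen on the ring nitrogen, so a 1-methylpiperidin-4-yl tail, a piperidin-1-yl tail or a piperidin-4-yl ring on a longer chain would leave open which of these carries the step.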